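A few compounds are considered here, and "the series" means these few. Any claim that something is new, unique, unknown or untested is made for them only; others in the source may bear on it.

Measured so far:
- compound 1, `Cc1ccccc1-n1nc(C)c2c1NC(=O)[C@H](C)S[C@@H]2c1ccc(-c2ccoc2)cc1`: 3500 nM
- compound 2, `COc1ccccc1-n1nc(C)c2c1NC(=O)[C@H](C)S[C@@H]2c1ccc(Oc2ccccc2)cc1`: 3300 nM

In an assay on isolated protein for agonist activity at Bile acid receptor (Homo sapiens), read by AlphaScreen, with a stated time of 30 min (on this read-out higher numbers stand for an effect only at larger amounts of compound and lower numbers for an effect already at smaller amounts), compound 1 gives 3500 nM. In this assay compound 2 gives 3300 nM, the lower of the two numbers, though the gap to compound 1 lies within the usual scatter, so the two read as alike.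

Compound 3, `CCc1ccccc1-n1nc(C)c2c1NC(=O)[C@H](C)S[C@@H]2c1ccc(Oc2ccccc2)cc1`, has not yet been measured in this assay. It differs from compound 2 in one place: ethyl in place of methoxy on an aromatic carbon. Going by the values given here, no measured pair shows this change, so its effect is open. Given that compounds 1 and 2, which carry methyl and methoxy at the same place and differ elsewhere as well, give numbers within the scatter of each other, no step beyond the scatter is expected from compound 2 to compound 3 in this assay, in either direction.

The estimated step is a 1.1-fold lower number from compound 2 to compound 3 (0.04 log units; within the scatter). Compound 3 is expected to give 3000 nM, within 1200 nM to 8000 nM.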

Compound 3, half-maximal effective concentration: 1100 nM
Compound 3: the middle estimate sits 2.7-fold (0.44 log units) above what was measured; the measured number lies below the stated range.
By their numbers in this assay, from the lowest: compound 3; then compounds 2 and 1 (each within the scatter of the next).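

In this assay, going by these compounds alone, ethyl in place of methoxy on an aromatic carbon, ortho to a large group, gives a 3.0-fold lower number from compound 2 to compound 3 (0.48 log units; beyond the scatter) and is the first change isolated at a single place. The number at this position therefore responds to which of these two groups it carries, a reading unavailable from compound 1 and compound 2, which differ in more than one place. This rests on one pair of compounds, and nothing available bears on what lies behind the step.

Still open, going by these compounds, is whether a longer chain such as propyl, or a polar group such as an amine or a carboxylic acid, would lower the number further or raise it at this position. On these data alone, it is also open whether the same change gives a similar step when the phenoxy group of compound 3 is replaced by the furan-bearing group of compound 1.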